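The compounds below may be only part of what the source reports. "The series", "measured", "known", "first", "only" and "open" are said of these compounds alone.

Measured compounds:
Compound 1 `CC(=O)Nc1ccc(O)c(C(=O)/C=C/c2ccc(F)cc2)c1`: 41100 nM
Compound 2 `CC(=O)Nc1ccc(O)c(C(=O)/C=C/c2ccc(C(F)(F)F)cc2)c1`: 21100 nM
Compound 3 `Nc1ccc2oc(-c3cccc(F)c3)cc(=O)c2c1`: 269000 nM

All three were tested in an ADME assay on MT4 cells (Homo sapiens) for cytotoxicity, read by MTT assay, with a stated time of 4 days; a higher number here means that more compound is tolerated, a lower number that less compound is tolerated. Compound 1 and compound 2 share one core and differ by a single change, (trifluoromethyl in place of fluoro on an aromatic carbon). That change gave a 1.9-fold lower number from compound 1 to compound 2 (0.29 log units; within the scatter), so the two numbers cannot be told apart with confidence. Compound 3 is built on a different core; how the two cores differ is not broken down here. What the values show is that compound 3 gives a higher number than compound 1, and a higher one still than compound 2, with both gaps beyond the usual scatter, so more of compound 3 is tolerated by the cells.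

Compound 4 `Nc1ccc2oc(-c3cccc(C(F)(F)F)c3)cc(=O)c2c1` has not yet been measured. It stands to compound 3 as compound 2 stands to compound 1: trifluoromethyl in place of fluoro on an aromatic carbon. Within the data shown here, the change is the same kind of change as the one from compound 1 to compound 2, though not the same, since there the new group sat para to a large group and here it sits meta to a large group. Among the measured compounds shown here, the earlier step is the only guide. Because a 1.9-fold lower number from compound 1 to compound 2 (0.29 log units; within the scatter) stayed within the scatter, the step from compound 3 to compound 4 is expected to be small as well, a 1.3-fold lower number from compound 3 to compound 4 (0.13 log units; within the scatter). For compound 4 the estimated value in this assay is therefore 200000 nM, with a plausible range from 90000 nM to 450000 nM.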

Compound 4, half-maximal cytotoxic concentration: 138000 nM
Beside the measured number, compound 4's estimate is 1.4-fold (0.16 log units) above it; the range from low to high includes it.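

In this assay, putting trifluoromethyl in place of fluoro on the core of compound 3 gave a 1.9-fold lower number from compound 3 to compound 4 (0.29 log units; within the scatter), so the two numbers cannot be told apart with confidence. The same swap on the core of compound 1 gave a matching result, and the two steps do not differ: the same change on two cores in this assay, a 1.9-fold lower number (0.29 log units; within the scatter) from compound 1 to compound 2 and a 1.9-fold lower number (0.29 log units; within the scatter) from compound 3 to compound 4, 1.0-fold (0.00 log units) apart, within the scatter of two such steps. What this shows is modest: on both cores shown, this swap made no difference that can be separated from the ordinary spread of repeated measurements, so the small step seen on one core was also seen on the other, but two pairs in a single cell assay do not establish a rule for other cores, and steps this small cannot show whether the swap has any real effect at all.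

The compounds shown leave open whether a quite different group on the same aromatic carbon, such as a carboxylic acid or a longer carbon chain, would move the tolerated concentration by more than the scatter. They also leave open whether trifluoromethyl and fluoro would stay this close on a third core.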